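The compounds below may be only part of what the source reports. "The series", "measured", "known", "first", "only" and "open" are said of these compounds alone.

Within the data shown here, in a functional assay on HeLa cells (Homo sapiens) for cytotoxicity, read by WST assay, with a stated time of 48 h (on this read-out higher numbers stand for weaker inhibition and lower numbers for stronger inhibition), compound 2 `COc1cc(C(c2ccc(O)c(OC)c2)[C@@H](C)[C@@H](C)CF)ccc1O` gives 42000 nM, the only true number in this set. Compound 1 `COc1cc(C(c2ccc(O)c(OC)c2)[C@H](C)[C@H](C)CO)ccc1O` reads > 100000 nM, which is a limit of the assay. Compound 3 `COC[C@@H](C)[C@@H](C)C(c1ccc(O)c(OC)c1)c1ccc(O)c(OC)c1` reads > 100000 nM, also a limit. Among the measured compounds shown here, two measured steps touch compound 2, each at least modest and beyond the scatter: an at least 2.3-fold lower number from compound 1 to compound 2 (0.37 log units; beyond the scatter), with 2-(fluoromethyl)-1-methylpropyl in place of 2-(hydroxymethyl)-1-methylpropyl, and an at least 2.3-fold higher number from compound 2 to compound 3 (0.37 log units; beyond the scatter), with 2-(methoxymethyl)-1-methylpropyl in place of 2-(fluoromethyl)-1-methylpropyl. Compound 4 `COc1cc(C(c2ccc(O)c(OC)c2)[C@@H](C)[C@H](C)CF)ccc1O` departs from compound 2 in configuration alone: the two compounds have the same atoms and bonds and differ only in configuration as drawn: 1 of 2 stereo elements differ; a stereocentre at a saturated chain carbon is drawn R in compound 2 and S in compound 4. For the measured compounds named here, no measured step changes configuration alone, so the expectation rests on compound 2 at 42000 nM. No step beyond the scatter is expected, and the estimated change is a 1.2-fold higher number from compound 2 to compound 4 (0.08 log units; within the scatter). For compound 4 the expected value is 50000 nM, within an estimated range of 20000 nM to 100000 nM.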

Compound 4, half-maximal inhibitory concentration: 37000 nM
The estimate for compound 4 lay 1.4-fold (0.13 log units) above the measured number, and the stated range covers the measured number.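

The configuration at this saturated chain carbon gives no step beyond the scatter in this assay, with a 1.1-fold lower number from compound 2 to compound 4 (0.06 log units; within the scatter), and this pair isolates that single change: the fact that compounds 2 and 4 differ only in the configuration as drawn. The fluoromethyl end keeps its edge in the new configuration, with an at least 2.7-fold lower number from compound 3 to compound 4 (0.43 log units; beyond the scatter) and an at least 2.7-fold lower number from compound 1 to compound 4 (0.43 log units; beyond the scatter). Both steps are only bounds, and their true sizes cannot be read: the limit of > 100000 nM in this assay, at which 2 of the 4 values shown sit.

As far as these compounds go, how an aminomethyl or carboxylic acid end would read at this position remains open. A longer chain carrying the fluorine is also untested in the compounds shown.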